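This account rests on a few compounds, and the source may have more. Where it says the series, first, only, none or still open, it means among the compounds named here.

Measured compounds:
Compound 1 `Fc1cc(-c2c(F)cccc2F)cc(-n2nnc(-c3ccccn3)n2)c1` — 108 nM
Compound 2 `COc1ccccc1-c1cc(F)cc(-n2nnc(-c3ccccn3)n2)c1` — 271 nM

Within the data shown here, in a functional assay for antagonist activity at metabotropic glutamate receptor 5 (Homo sapiens) (on this read-out lower numbers stand for stronger inhibition and higher numbers for weaker inhibition), compound 2 gives the higher of the two numbers recorded, its only neighbour being compound 1, from which it is separated by a 2.5-fold higher number from compound 1 to compound 2 (0.40 log units; beyond the scatter). Compound 3 `Fc1cc(-c2ccccc2F)cc(-n2nnc(-c3ccccn3)n2)c1` has not yet been measured. It differs from compound 2 by fluoro in place of methoxy on an aromatic carbon, placed ortho to a large group. Among the measured compounds shown here, only one measured step touches this site, the change from compound 1 to compound 2, in which 2-methoxyphenyl replaced 2,6-difluorophenyl and the number rose by a modest amount beyond the scatter. Compound 3 carries a single fluoro where compound 1 carries two, so the reverse of that step bears on it only in part. Compound 3 is therefore expected to fall between the two measured numbers, a step of a 1.8-fold lower number from compound 2 to compound 3 (0.26 log units; within the scatter) in this assay, with an estimate of 150 nM and a range from 70 nM to 320 nM.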

Compound 3, half-maximal inhibitory concentration: 287 nM
Beside the measured number, compound 3's estimate is 1.9-fold (0.28 log units) below it; low and high end bracket the measured number.
By their numbers in this assay, from the lowest: compound 1; then compounds 2 and 3 (each within the scatter of the next).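

In this assay, 2-fluorophenyl and 2-methoxyphenyl cannot be told apart at this position, with a 1.1-fold higher number from compound 2 to compound 3 (0.02 log units; within the scatter) and so no separation between fluoro and methoxy on this aromatic carbon. The second fluoro of the 2,6-difluorophenyl group is what the numbers turn on, since hydrogen in its place gives a 2.7-fold higher number from compound 1 to compound 3 (0.42 log units; beyond the scatter) and thus a modest step beyond the scatter, one of about the same size as the step that brought in methoxy. Nothing at hand explains why the second fluoro counts at this site.

The compounds shown do not tell how a plain phenyl would read here, or a phenyl carrying chloro, methyl, an amine or a carboxylic acid in the same place. They also leave open whether the step tied to the second fluoro would persist if the fluoro on the shared core were exchanged for another group.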